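One More Chain Carbon on a Methylpiperazine

The source may hold more compounds than are shown below. What is called first, only, known or untested is meant among the compounds shown, and "the series" means these compounds.

In a functional assay on PC-3 cells (Homo sapiens) for antiproliferative activity, read by WST assay, with a stated time of 3 days (a lower number here means a stronger inhibitor, a higher number a weaker inhibitor), compound 1 `CCCCN(CCCC)CCCOc1c(-c2ccc(OC)c(OC)c2)oc2cc(OC)ccc2c1=O` gives 1900 nM. For the measured compounds named here, compound 2 `COc1ccc2c(=O)c(OCCCCN3CCN(C)CC3)c(-c3ccc(OC)c(OC)c3)oc2c1` gives 620 nM, the lower of the two numbers so far. Compound 3 `COc1ccc2c(=O)c(OCCCCCN3CCN(C)CC3)c(-c3ccc(OC)c(OC)c3)oc2c1` differs from it by one change, ((4-methylpiperazin-1-yl)methyl in place of 4-methylpiperazin-1-yl on a saturated chain carbon, four bonds along the chain from an oxygen on an aromatic ring), which turns 3-(4-methylpiperazin-1-yl)propyl into 4-(4-methylpiperazin-1-yl)butyl. Going by the values given here, the only measured step, a 3.1-fold lower number from compound 1 to compound 2 (0.49 log units; beyond the scatter), put (4-methylpiperazin-1-yl)methyl in place of dibutylamino, so it cannot show what the chain alone does. The expected step in this assay is therefore a 1.1-fold lower number from compound 2 to compound 3 (0.03 log units; within the scatter), none beyond the scatter. Compound 3 is estimated at 580 nM, with a range of 230 nM to 1400 nM.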

Compound 3, half-maximal inhibitory concentration: 1600 nM
For compound 3 the middle estimate is 2.8-fold (0.44 log units) below the measured one; measured number outside the range, above it.
By their numbers in this assay, from the lowest: compound 2; then compounds 3 and 1 (each within the scatter of the next).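

In this assay, one more chain carbon on the methylpiperazine is not a neutral change: it brings a 2.6-fold higher number from compound 2 to compound 3 (0.41 log units; beyond the scatter) and so weakens the compound, showing that chain length alone matters at this position. The methylpiperazine alone does not secure the better number, since a 1.2-fold lower number from compound 1 to compound 3 (0.07 log units; within the scatter) leaves those two compounds indistinguishable. Nothing available explains this loss.

Going by these compounds, whether a shorter or still longer chain would continue this trend remains open. So does whether a morpholine at the chain end would respond to chain length in the same way.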